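The source may report more compounds than this note shows. Statements on the series, on what has been measured and on what is new or still open speak of the compounds shown alone.

Working notes on the series. In a functional assay on A549 cells (Homo sapiens) for cytotoxicity, read by MTT assay, with a stated time of 48 h (on this read-out higher numbers stand for weaker inhibition and lower numbers for stronger inhibition), compound 1 (`COc1cc(C2=NOC(c3cc(OC)c(OC)c(OC)c3)C2)ccc1O`) gives 2600 nM, compound 2 (`COc1cc(C2=NOC(COc3ccc(-c4nnnn4-c4cc(OC)c(OC)c(OC)c4)cc3N)C2)cc(OC)c1OC`) gives 2060 nM and compound 3 (`COc1ccc(-c2nnnn2-c2cc(OC)c(OC)c(OC)c2)cc1N`) gives 2630 nM. Compound 2 stands within the scatter of both compound 1 and compound 3, so these three numbers do not separate the compounds. Among the measured compounds shown here, no pair of measured compounds differs in one place only, so the size of a single change has not been measured.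

Compound 4 (`COc1ccc(C2=NOC(COc3ccc(-c4nnnn4-c4cc(OC)c(OC)c(OC)c4)cc3N)C2)cc1[N+](=O)[O-]`) is still unmeasured. Compared with compound 2, it has 4-methoxy-3-nitrophenyl in place of 3,4,5-trimethoxyphenyl on a carbon with a double bond to nitrogen.

In this assay, no step beyond the scatter is expected. This expectation rests only on the close agreement of the three measured values, with compound 2 at 2060 nM as the starting point. For the measured compounds named here, the data hold no measured example of this replacement, so the range is kept wide. The estimated change, a 1.2-fold higher number from compound 2 to compound 4 (0.07 log units; within the scatter), is a small move towards a higher number and lies inside the scatter. For compound 4 the expected value is 2400 nM. The estimated range for compound 4 runs from 900 nM to 6500 nM.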

Compound 4, half-maximal inhibitory concentration: 2220 nM
Estimate against measurement, compound 4: 1.1-fold (0.03 log units) above, within the range that was stated.
By their numbers in this assay, from the lowest: compounds 2, 4, 1 and 3 (each within the scatter of the next).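

In this assay, the series now has its first single replacement, a 1.1-fold higher number from compound 2 to compound 4 (0.03 log units; within the scatter), so exchanging 3,4,5-trimethoxyphenyl for 4-methoxy-3-nitrophenyl on a carbon with a double bond to nitrogen gives no step beyond the scatter. At this place on the five-membered non-aromatic ring with one nitrogen and one oxygen, this read-out therefore does not separate the two substituted phenyl groups, although one carries a nitro group and the other three methoxy groups. Nothing available gives a measured property that could account for this result.

This single pair leaves open whether the read-out responds to any replacement at this place, and an unsubstituted phenyl, an aminophenyl, a carboxylic acid or a longer alkyl chain on the same carbon would test a wider range of groups. It also leaves open whether the amino group on the central benzene ring or the 3,4,5-trimethoxyphenyl on the tetrazole contributes to the values in this assay, which a hydroxyl group or a methyl group in those places would help to show.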